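A few compounds are considered here, and "the series" means these few. Any claim that something is new, unique, unknown or untested is made for them only; others in the source may bear on it.

Compound 2, built as `O=C1N=C(N2N=C(c3ccccc3)CC2c2ccc(Cl)cc2)S/C1=C1/C(=O)Nc2ccccc21`, gives 70800 nM in a functional assay on cells (Leukemia cell, Homo sapiens) for cytotoxicity, read by sulforhodamine B assay, with a stated time of 48 h; a lower number here means a stronger inhibitor of growth, a higher number a weaker inhibitor of growth. Its nearest neighbour on the numbers shown is compound 1, `O=C1N=C(N2N=C(c3ccccc3)CC2c2ccccc2O)S/C1=C1/C(=O)Nc2ccccc21`, which in this assay gives 48800 nM; the move a 1.5-fold higher number from compound 1 to compound 2 (0.16 log units; within the scatter) stays within the scatter, so the two values cannot be told apart. Compound 3, `Cc1ccc2c(c1)/C(=C1\SC(N3N=C(c4ccccc4)CC3c3ccc(Cl)cc3)=NC1=O)C(=O)N2`, gives 39400 nM in this assay, and the move a 1.8-fold lower number from compound 2 to compound 3 (0.25 log units; within the scatter) is likewise within the scatter. Compound 2 therefore stands among three values that are indistinguishable from one another.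

Compound 4 is `O=C1N=C(N2N=C(c3ccc4ccccc4c3)CC2c2ccc(Cl)cc2)S/C1=C1/C(=O)Nc2ccccc21`. Compared with compound 2 the change is naphthalen-2-yl in place of phenyl on a carbon with a double bond to nitrogen. Neither measured step touches this position: the step from compound 1 to compound 2 alters the group on the saturated ring carbon, and the step from compound 2 to compound 3 alters an aromatic hydrogen of the shared core. Both steps were within the scatter, and nothing in the data points to a move beyond it for the new aromatic group. The expected step in this assay is therefore small, a 1.2-fold lower number from compound 2 to compound 4 (0.07 log units; within the scatter), with no direction that can be trusted. Compound 4 is estimated at 60000 nM, within a range from 20000 nM to 180000 nM.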

Compound 4, concentration for total growth inhibition: 71600 nM
Estimate against measurement, compound 4: 1.2-fold (0.08 log units) below; the range from low to high includes it.
By their numbers in this assay, from the lowest: compounds 3, 1, 2 and 4 (each within the scatter of the next).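

This is the first change shown at the carbon with a double bond to nitrogen, and in this assay it gives a step of a 1.0-fold higher number from compound 2 to compound 4 (0.00 log units; within the scatter). Naphthalen-2-yl, with two six-membered aromatic rings of carbon only, can therefore stand in place of phenyl, with its one such ring, at this position, with the 4-chlorophenyl group held constant, and the assay does not resolve any difference between the two. No other kind of measurement is available to bear on this result.

What the compounds shown leave open is whether any group on this carbon can move the number beyond the scatter, since only two aromatic groups of carbon only are compared here, and an amine, a carboxylic acid or a longer chain at the same place would test something different. From the compounds shown here alone, it also remains open whether the same swap would give a similar result alongside the 2-hydroxyphenyl group of compound 1 or the added methyl of compound 3, since this position is compared only with the 4-chlorophenyl group and the unmethylated core.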